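Methoxy in place of trifluoromethoxy: an expected small step

The compounds below may be only part of what the source reports. "The series", "measured", "known", "first", "only" and "open" are said of these compounds alone.

Measured compounds:
compound 1, `O=c1oc2cc(-c3cnc4[nH]ccc4c3)ccc2n1Cc1ccc(F)cc1`, 5990 nM
compound 2, `O=c1oc2cc(-c3cnc4[nH]ccc4c3)ccc2n1Cc1cccc(OC(F)(F)F)c1`, 7060 nM

Both compounds were tested in a functional assay on HCT-116 cells (Homo sapiens) for inhibition, read by MTT assay, with a stated time of 72 h; a lower number here means a stronger inhibitor, a higher number a weaker inhibitor. On paper compound 2 carries the larger of the two numbers, but its gap to compound 1 falls inside the usual scatter of repeated measurements, so the two compounds cannot be told apart on these data. Neither one can be called stronger or weaker than the other.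

Compound 3, `COc1cccc(Cn2c(=O)oc3cc(-c4cnc5[nH]ccc5c4)ccc32)c1`, has not yet been measured. It differs from compound 2 in a single place: methyl in place of trifluoromethyl on an oxygen on an aromatic ring. Everything else in the structure stays the same.

Going by the values given here, no pair of measured compounds shows the effect of this particular swap, so there is no measured step to lean on. The two measured compounds sit close together despite carrying different groups on the same ring, which gives no hint of a large movement in either direction. The expectation is therefore a step of no more than the scatter, a 1.1-fold lower number from compound 2 to compound 3 (0.04 log units; within the scatter). Compound 3 is estimated at 6500 nM, with a range from 2500 nM to 16000 nM.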

Compound 3, half-maximal inhibitory concentration: 5000 nM
Beside the measured number, compound 3's estimate is 1.3-fold (0.11 log units) above it, and the stated range covers the measured number.
By their numbers in this assay, from the lowest: compounds 3, 1 and 2 (each within the scatter of the next).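

In this assay, going by these compounds alone, trifluoromethoxy to methoxy on the aromatic ring gives a 1.4-fold lower number from compound 2 to compound 3 (0.15 log units; within the scatter), the first measured reading of this swap. Four heavy atoms leave and one enters, yet the two compounds cannot be told apart on this read-out, so at this place the trifluoromethyl and the methyl on the oxygen are not distinguished by the assay. The link to the remaining compound, 3-methoxyphenyl in place of 4-fluorophenyl on a saturated chain carbon bound to an aromatic nitrogen, gives a 1.2-fold lower number from compound 1 to compound 3 (0.08 log units; within the scatter), so all three compounds form one group within the scatter, and nothing measured here offers an explanation for that.

As far as these compounds go, it remains open whether any group on this ring can move the number beyond the scatter, in either direction, since each change seen so far stays within it. A longer chain on the oxygen, such as ethyl or propyl, or an amine or a carboxylic acid on the same ring, would show whether this part of the molecule matters to the read-out at all.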